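Swapping the halogen-bearing phenyl group of compound 1

This account rests on a few compounds, and the source may have more. Where it says the series, first, only, none or still open, it means among the compounds named here.

Measured in a functional assay (on this read-out lower numbers stand for stronger inhibition and higher numbers for weaker inhibition), so far:
- compound 1 `CC(C)=CCOc1ccc2c(c1)OC(c1ccccc1Cl)CC2=O` gives 8020 nM
- compound 2 `CC(C)=CCOc1ccc2c(c1)OC(c1ccc(Cl)cc1)CC2=O` gives 6970 nM
- compound 3 `CC(C)=CCOc1ccc2c(c1)OC(c1ccc(Cl)cc1Cl)CC2=O` gives 5260 nM

Compound 1 sits level with the other two, as the steps of a 1.2-fold lower number from compound 1 to compound 2 (0.06 log units; within the scatter) and a 1.5-fold lower number from compound 1 to compound 3 (0.18 log units; within the scatter) show. Compound 4 `CC(C)=CCOc1ccc2c(c1)OC(c1cccc(Br)c1)CC2=O` has not yet been measured. Its difference from compound 1 is 3-bromophenyl in place of 2-chlorophenyl on a saturated ring carbon and in words this is 3-bromophenyl in place of 2-chlorophenyl on a saturated ring carbon, next to the ring oxygen.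

The closest evidence is the change at that same carbon, a 1.2-fold lower number from compound 1 to compound 2 (0.06 log units; within the scatter) in size. Adding a chloro group gave a 1.3-fold lower number from compound 2 to compound 3 (0.12 log units; within the scatter) and so this change was small as well. Among the compounds with values here, no compound with bromine has been measured, which leaves the forecast uncertain. Even so, no step beyond the scatter is expected, and the estimated step is a 1.2-fold lower number from compound 1 to compound 4 (0.09 log units; within the scatter) in this forecast. For compound 4 the estimated value is 6500 nM with an expected range from 3000 nM to 14000 nM in this assay.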

Compound 4, half-maximal inhibitory concentration: 5280 nM
Compound 4: the middle estimate sits 1.2-fold (0.09 log units) above what was measured; low and high end bracket the measured number.
By their numbers in this assay, from the lowest: compounds 3, 4, 2 and 1 (each within the scatter of the next).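

Bromine now appears for the first time on the phenyl group on this saturated ring carbon, and in this assay the 3-bromophenyl group stays within the scatter of all three chlorine-bearing groups (a 1.5-fold lower number from compound 1 to compound 4 (0.18 log units; within the scatter); a 1.3-fold lower number from compound 2 to compound 4 (0.12 log units; within the scatter); a 1.0-fold higher number from compound 3 to compound 4 (0.00 log units; within the scatter)). The change from compound 1 swaps the halogen and its place on the phenyl group together, and these results do not separate the two. No supporting measurement bears on why these four compounds read alike.

The compounds shown all carry a halogen on this phenyl group. As far as these compounds go, it remains open whether a plain phenyl group, or a phenyl group carrying an amine or a carboxylic acid, would stay within the scatter or move the number beyond it.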